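Series notes: replacing the fluoropiperidine on the core of compound 1

The compounds below may be only part of what the source reports. "The series", "measured", "known", "first", "only" and "open" are said of these compounds alone.

Compound 1 `O=C(Nc1ccnnc1)c1cc(N2CCC(F)CC2)ccc1OCc1ccccc1` and compound 2 `O=C(Nc1cccc(Cl)c1)c1cc(C(F)(F)F)ccc1OCc1ccccc1` share a benzyloxy-bearing core and have both been run in a physicochemical assay for lipophilicity, at pH 7.4; on this read-out lower numbers stand for lower lipophilicity and higher numbers for higher lipophilicity. In this assay compound 1 gives 5.1, the lower of the two numbers, while compound 2 gives 8.8, a number that stands beyond the scatter above it. Within the data shown here, no single-change pair links these two, so nothing more is read from them than the values themselves.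

Compound 3 `CN1CC2(CCN(c3ccc(OCc4ccccc4)c(C(=O)Nc4ccnnc4)c3)CC2)C1` has not yet been measured. It differs from compound 1 in one place: a group of 10 heavy atoms (8 carbon, 2 nitrogen; one four-membered non-aromatic ring with 1 hetero atom, one six-membered non-aromatic ring with 1 hetero atom) in place of a group of 7 heavy atoms (5 carbon, 1 nitrogen, 1 fluorine; one six-membered non-aromatic ring with 1 hetero atom), on an aromatic carbon The entering group brings two nitrogens and a second hydrogen-bond acceptor where the leaving group carried one nitrogen and a fluorine.

Among the measured compounds shown here, no measured step of this kind exists, so the expectation rests on compound 1 alone. The step from compound 1 to compound 3 in this assay is expected to be a clear decrease, a number 1.90 log units lower from compound 1 to compound 3 (beyond the scatter), beyond the scatter. Compound 3 is therefore estimated at 3.2, with a range from 2.2 to 4.2.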

Compound 3, distribution coefficient: 2.2
Compound 3: middle estimate off by 1.00 log units, on the high side; the range from low to high includes it.
By their numbers in this assay, from the lowest: compound 3; then compound 1; then compound 2.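

At the position para to a benzyloxy group and meta to a (pyridazin-4-yl)carbamoyl group, the series now has its first single-change step in this assay. Exchanging 4-fluoropiperidin-1-yl for the two-ring group with its four-membered ring gives a large step (a number 2.90 log units lower from compound 1 to compound 3 (beyond the scatter)), so a change at this position alone moves the read-out clearly on the core of compound 1. No supporting data bear on which part of the exchange carries the step.

Still open, as far as these compounds go, is where a morpholine or an unsubstituted piperidine at this position would fall, which would help separate the loss of the fluorine from the gain of the second ring. Also open, from the compounds shown here alone, is whether the same exchange gives a step of similar size with a chlorophenyl amide in place of the (pyridazin-4-yl)carbamoyl group.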